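Swapping the carbamate ester group on a shared core

The source may report more compounds than this note shows. Statements on the series, on what has been measured and on what is new or still open speak of the compounds shown alone.

Three compounds share one core and differ only in the group on an oxygen next to a carbonyl group. Compound 1 `Cc1nc(S(C)(=O)=O)ccc1Oc1ncnc(OC2CCN(C(=O)OC3CCC3)CC2)c1F` carries a cyclobutyl there and gives 167 nM in a functional assay on isolated protein for inhibition of Glucose-dependent insulinotropic receptor (Rattus norvegicus), read by HTRF and cAMP accumulation; a lower number here means that less compound is needed, a higher number that more compound is needed for the effect. Compound 2 `Cc1nc(S(C)(=O)=O)ccc1Oc1ncnc(OC2CCN(C(=O)OC(C)(C)C#N)CC2)c1F` carries a 1-cyano-1-methylethyl and gives 1320 nM. Compound 3 `CCC1(OC(=O)N2CCC(Oc3ncnc(Oc4ccc(S(C)(=O)=O)nc4C)c3F)CC2)CC1` carries a 1-ethylcyclopropyl and gives 333 nM, which places it between the other two: the change a 2.0-fold higher number from compound 1 to compound 3 (0.30 log units; within the scatter) lies within the scatter, whereas a 4.0-fold lower number from compound 2 to compound 3 (0.60 log units; beyond the scatter) is a real improvement.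

Compound 4 `Cc1nc(S(C)(=O)=O)ccc1Oc1ncnc(OC2CCN(C(=O)OC3(C(F)(F)F)CCC3)CC2)c1F` is the next member. The change is 1-(trifluoromethyl)cyclobutyl in place of 1-ethylcyclopropyl on an oxygen next to a carbonyl group. The three measured steps show that this position tolerates small rings well, since a 7.9-fold higher number from compound 1 to compound 2 (0.90 log units; beyond the scatter) was the only clearly harmful move, and it introduced a nitrile rather than a ring. For the measured compounds named here, a cyclobutyl bearing a trifluoromethyl has no direct precedent here, so the expectation is a step of a 1.1-fold lower number from compound 3 to compound 4 (0.05 log units; within the scatter), that is, no change beyond the scatter. Compound 4 is therefore estimated at 300 nM, with a range from 90 nM to 1000 nM.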

Compound 4, half-maximal effective concentration: 63.3 nM
Compound 4: middle estimate off by 4.7-fold (0.68 log units), on the high side, and the stated range ends above it.
By their numbers in this assay, from the lowest: compound 4; then compounds 1 and 3 (each within the scatter of the next); then compound 2.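

The earlier steps shown here showed this position only holding the number or raising it from the cyclobutyl, but trifluoromethyl in place of hydrogen on a saturated ring carbon gives a 2.6-fold lower number from compound 1 to compound 4 (0.42 log units; beyond the scatter) in this assay and so shows that the number can also fall. The swap from 1-ethylcyclopropyl gives a 5.3-fold lower number from compound 3 to compound 4 (0.72 log units; beyond the scatter) and so shows that carrying an extra group on the ring does not by itself decide the outcome. The swap from 1-cyano-1-methylethyl gives a 21-fold lower number from compound 2 to compound 4 (1.32 log units; beyond the scatter) and so widens the spread among these four compounds well beyond what the earlier ones showed.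

The compounds shown leave open whether the trifluoromethyl or the four-membered ring accounts for the difference from compound 3, which a 1-(trifluoromethyl)cyclopropyl or a 1-methylcyclobutyl would help to separate. No measurement given here explains why the number falls.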